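From 4-fluorophenyl to 3-fluorophenyl on the shared core

This account rests on a few compounds, and the source may have more. Where it says the series, first, only, none or still open, it means among the compounds named here.

Compound 1 `Fc1cccc(-c2nc(Nc3ccccc3)c3cc(F)ccc3n2)c1`: 48300 nM
Compound 2 `Fc1ccc(Nc2nc(-c3cccc(F)c3)nc3ccc(F)cc23)cc1`: > 50000 nM (a limit)

In a functional assay on HL-60 cells (Homo sapiens) for cytotoxicity, read by MTT assay, with a stated time of 48 h (a lower number here means a stronger inhibitor, a higher number a weaker inhibitor), compound 2 stands at a limit of the assay and not at a number. Compound 3 `Fc1cccc(Nc2nc(-c3cccc(F)c3)nc3ccc(F)cc23)c1` differs from it as follows: 3-fluorophenyl in place of 4-fluorophenyl on a nitrogen on an aromatic ring. The change is 3-fluorophenyl in place of 4-fluorophenyl on a nitrogen on an aromatic ring. For the measured compounds named here, one measured step bears on it, an at least 1.0-fold higher number from compound 1 to compound 2 (0.01 log units; that floor lies within the scatter), which places fluoro in place of hydrogen on an aromatic carbon. Going by the values given here, with only that step to go on, no change beyond the scatter is expected in this assay. The expected step is an at least 1.1-fold lower number from compound 2 to compound 3 (0.04 log units; that floor lies within the scatter), an estimate only. For compound 3 the estimated value is 45000 nM, with an expected range from 20000 nM to 100000 nM.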

Compound 3, half-maximal inhibitory concentration: 43100 nM
Estimate against measurement, compound 3: 1.0-fold (0.02 log units) above, within the range that was stated.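

In this assay compound 2 is a limit and not a number: the limit of > 50000 nM in this assay, at which 1 of the 3 values shown sits. The change from 4-fluorophenyl to 3-fluorophenyl can therefore be read only as a floor, an at least 1.1-fold lower number from compound 2 to compound 3 (0.06 log units; that floor lies within the scatter). Compound 3 has a measured value, so a fluoro on this ring can now be compared directly with hydrogen, and the result is a 1.1-fold lower number from compound 1 to compound 3 (0.05 log units; within the scatter).

The compounds shown leave open whether the ring on this nitrogen tolerates anything other than hydrogen or fluoro. An amine or a carboxylic acid in place of the fluoro might move the number beyond the scatter.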